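The source may report more compounds than this note shows. Statements on the series, on what has been measured and on what is new or still open speak of the compounds shown alone.

Measured compounds:
compound 1, `O=C(Nc1ccccc1C(F)(F)F)C1CCc2ccccc2N1C(=O)c1cccc(Cl)c1`, 526 nM
compound 2, `O=C(Nc1ccccc1)C1CCc2ccccc2N1`, 72900 nM
compound 3, `CC(=O)N1c2ccccc2CCC1C(=O)Nc1cc(C(F)(F)F)cc(C(F)(F)F)c1`, > 70000 nM

All three were tested in a functional assay on ACHN cells (Homo sapiens) for cytotoxicity, read by sulforhodamine B assay, with a stated time of 72 h; a lower number here means a stronger inhibitor of growth, a higher number a weaker inhibitor of growth. Compound 1 gives 526 nM, and compound 2 gives 72900 nM. For compound 3 the result is > 70000 nM, which is a limit of the assay and not a number; compound 3 therefore sits at the limit of > 70000 nM in this assay, at which 1 of the 3 values shown sits, with no figure of its own.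

Compound 4, `O=C(Nc1cc(C(F)(F)F)cc(C(F)(F)F)c1)C1CCc2ccccc2N1C(=O)c1ccccc1Cl`, has not yet been measured. It is compound 3 with one change: 2-chlorophenyl in place of methyl on a carbonyl carbon. Everything else in compound 3 is kept.

Going by the values given here, no two measured compounds differ in exactly one place, so no measured step can be read off directly. Still, compound 1 is the only one of the three with a clear number and it carries an aromatic ring on the corresponding carbonyl, which suggests the expected direction: the step of an at least 23-fold lower number from compound 3 to compound 4 (1.36 log units; beyond the scatter) is expected to lower the number considerably, beyond the usual scatter, because compound 1 gives 526 nM. Compound 4 is therefore estimated at 3000 nM, with a likely range from 400 nM to 30000 nM.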

Compound 4, concentration for 50% growth inhibition: 4700 nM
Compound 4: middle estimate off by 1.6-fold (0.19 log units), on the low side; measured number inside the range.
By their numbers in this assay, from the lowest: compound 1; then compound 4; then compound 2.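

In this assay, 2-chlorophenyl in place of methyl on a carbonyl carbon gives an at least 14-fold lower number from compound 3 to compound 4 (1.17 log units; beyond the scatter), with the rest of the molecule kept. Going by these compounds alone, this is the first single change that can be read directly, and it shows that the group on this carbonyl can by itself move a compound from the limit of the assay to a measurable number. For compound 3 the result of > 70000 nM is a limit of the assay and not a number. The step is therefore a minimum and its true size remains unknown, because one end of it rests on that limit: the limit of > 70000 nM in this assay, at which 1 of the 4 values shown sits.

On these data alone, whether the drop depends on the chlorine, on the aromatic ring or simply on a larger group stays open, and a plain phenyl or a straight hexyl chain on the same carbonyl would help to separate these. Compound 1 and compound 4 differ in more than one place, so their values say nothing direct about how the chlorine's placement or the trifluoromethyl groups contribute.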